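A few compounds are considered here, and "the series" means these few. Any claim that something is new, unique, unknown or untested is made for them only; others in the source may bear on it.

Compound 1 `CCOC(=O)CNC(C)(C)CC(=O)N[C@@H]1CCc2ccccc2N(Cc2ccc(-c3ccccc3-c3nn[nH]n3)cc2)C1=O` gives 56 nM in a functional assay (Pituitary gland cell) with Rattus norvegicus as the target; a lower number here means that less compound is needed, a higher number that more compound is needed for the effect. Compound 2 `CC(C)(CC(=O)N[C@@H]1CCc2ccccc2N(Cc2ccc(-c3ccccc3-c3nn[nH]n3)cc2)C1=O)NCCO` gives 30 nM in this assay. Compound 3 `CC(C)[C@@H](O)CNC(C)(C)CC(=O)N[C@@H]1CCc2ccccc2N(Cc2ccc(-c3ccccc3-c3nn[nH]n3)cc2)C1=O` gives 200 nM in this assay.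

Compound 3 therefore stands at the highest number of the three: a 3.6-fold higher number from compound 1 to compound 3 (0.55 log units; beyond the scatter) and a 6.7-fold higher number from compound 2 to compound 3 (0.82 log units; beyond the scatter). Compound 4 `CC(C)(CC(=O)N[C@@H]1CCc2ccccc2N(Cc2ccc(-c3ccccc3-c3nn[nH]n3)cc2)C1=O)NC[C@H](O)CO` differs from compound 3 in one place: hydroxymethyl in place of isopropyl on a saturated chain carbon bound to an oxygen on a saturated carbon and a saturated chain carbon. Within the data shown here, the step that bears on this most directly is the one between compound 2 and compound 3 at the same carbon, where the isopropyl entered and the number rose beyond the scatter: a 6.7-fold higher number from compound 2 to compound 3 (0.82 log units; beyond the scatter). Taking the isopropyl away again and putting a hydroxymethyl in its place is expected to move the number back down, toward compound 2. Compound 4 is thus expected at 40 nM, in a range from 15 nM to 120 nM, a step of a 5.0-fold lower number from compound 3 to compound 4 (0.70 log units; beyond the scatter).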

Compound 4, concentration for half-maximal effect: 10 nM
For compound 4 the middle estimate is 4.0-fold (0.60 log units) above the measured one; the whole stated range lies above it.
By their numbers in this assay, from the lowest: compound 4; then compounds 2 and 1 (each within the scatter of the next); then compound 3.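

The hydroxymethyl does more at this carbon than cancel the isopropyl (a 20-fold lower number from compound 3 to compound 4 (1.30 log units; beyond the scatter)): it also gives a lower number than the hydrogen of compound 2 (a 3.0-fold lower number from compound 2 to compound 4 (0.48 log units; beyond the scatter)), so a group here can move the number in either direction. The 1,2-dihydroxyethyl also gives a lower number than the ethoxycarbonyl (a 5.6-fold lower number from compound 1 to compound 4 (0.75 log units; beyond the scatter)). No measurement available here explains these differences.

As far as these compounds go, how a methyl, an amine or a carboxylic acid at this carbon would compare with the hydroxymethyl remains open. So does whether the oxygen of the hydroxymethyl matters at all.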